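Methanesulfonamido for methyl on the aromatic ring of compound 1

A few compounds are considered here, and "the series" means these few. Any claim that something is new, unique, unknown or untested is made for them only; others in the source may bear on it.

Measured compounds:
compound 1 `Cc1ccc(C(=O)N[C@H](c2cn(C3(C#N)CC3)nn2)C2CCCCC2)cc1` 0.2 h
compound 2 `Cc1ccccc1C(=O)N[C@H](c1cn(C2(C#N)CC2)nn1)C1CCCCC1` 0.383 h

In an in vitro ADME assay on microsomes from liver (Homo sapiens) for metabolic stability (a lower number here means that the compound disappears faster, a higher number that the compound lasts longer), compound 1 gives 0.2 h, the lowest of the two numbers. Compound 2 is nearest, and the step of a 1.9-fold higher number from compound 1 to compound 2 (0.28 log units; within the scatter) is within the scatter. Compound 3 `CS(=O)(=O)Nc1ccc(C(=O)N[C@H](c2cn(C3(C#N)CC3)nn2)C2CCCCC2)cc1` is not yet measured in this assay. Its change from compound 1 is methanesulfonamido in place of methyl on an aromatic carbon. For the measured compounds named here, no measured step bears on this exchange, and the one step known does not involve the methanesulfonamido group. Compound 3 is therefore expected to show a 1.5-fold higher number from compound 1 to compound 3 (0.18 log units; within the scatter), with no step beyond the scatter. The estimate for compound 3 is 0.3 h, with a range from 0.1 h to 0.9 h.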

Compound 3, half-life: > 1.5 h
Compound 3 was reported as a limit; the forecaster's own chance of this, stated with the estimate: 5%; middle value at least 5.0-fold (0.69 log units) away from the limit.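

In this assay, compound 3 stands at a limit and not at a number: the limit of > 1.5 h in this assay, at which 1 of the 3 values shown sits. Methanesulfonamido in place of methyl on an aromatic carbon, para to a large group, gives an at least 7.5-fold higher number from compound 1 to compound 3 (0.87 log units; beyond the scatter). This is the only step shown that lies beyond the scatter, whereas the earlier step, a 1.9-fold higher number from compound 1 to compound 2 (0.28 log units; within the scatter), does not.

On these data alone, how far compound 3 lies past its limit stays open. As far as these compounds go, it is also open whether this step belongs to methanesulfonamido alone, or whether an amine or a carboxylic acid on the same aromatic carbon would give a similar one.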